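Dropping a Methoxy Group: Expected Effect on Inhibition

The source may report more compounds than this note shows. Statements on the series, on what has been measured and on what is new or still open speak of the compounds shown alone.

The compounds were compared in a functional assay on cells (Erythrocyte, Homo sapiens); a lower number here means a stronger inhibitor, a higher number a weaker inhibitor. Compound 1 `COc1ccc2[nH]c(S(=O)(=O)Cc3ccc(OCc4nccc(OC)c4OC)c(OC)c3)nc2c1` gives 898 nM. Compound 2 `COCCCOc1ccnc(COc2ccc(CS(=O)(=O)c3nc4cc(OC)ccc4[nH]3)cc2OC)c1C` gives 817 nM in this assay, a value that lies within the scatter of that of compound 1. Compound 3 `COCCCOc1ccnc(COc2ccc(CS(=O)(=O)c3nc4ccccc4[nH]3)cc2OC)c1C` gives 355 nM in this assay. How the cores of compound 1 and compound 2 differ is not broken down here.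

Between compound 2 and compound 3 the only change is hydrogen in place of methoxy on an aromatic carbon, and it produced a 2.3-fold lower number from compound 2 to compound 3 (0.36 log units; beyond the scatter). For the measured compounds named here, compound 4 `COc1cc(CS(=O)(=O)c2nc3ccccc3[nH]2)ccc1OCc1nccc(OC)c1OC` has not yet been measured in this assay; it differs from compound 1 by hydrogen in place of methoxy on an aromatic carbon, the same change at the same place as the one that separates compound 2 from compound 3.

Resting on that single precedent, the step from compound 1 to compound 4 in this assay is expected to be of similar size, a 2.3-fold lower number from compound 1 to compound 4 (0.36 log units; beyond the scatter), because the step of a 2.3-fold lower number from compound 2 to compound 3 (0.36 log units; beyond the scatter) was seen for the same change. Compound 4 is therefore estimated to give 390 nM in this assay, with a likely range from 180 nM to 850 nM. Going by the values given here, with only one prior example of this change, the width of that range reflects the usual scatter of such measurements.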

Compound 4, half-maximal inhibitory concentration: 212 nM
Estimate against measurement, compound 4: 1.8-fold (0.26 log units) above; the range from low to high includes it.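

In this assay, replacing the methoxy group with hydrogen again lowered the number, a 4.2-fold lower number from compound 1 to compound 4 (0.63 log units; beyond the scatter), so the change from 5-methoxy-1H-benzimidazol-2-yl to 1H-benzimidazol-2-yl went the same way on both cores, and the two steps agree in size within the scatter: the same change on two cores in this assay, a 2.3-fold lower number (0.36 log units; beyond the scatter) from compound 2 to compound 3 and a 4.2-fold lower number (0.63 log units; beyond the scatter) from compound 1 to compound 4, 1.8-fold (0.26 log units) apart, within the scatter of two such steps. The change thus carried over from the core of compound 2 to the core of compound 1, in direction and, as far as two steps can tell, in size. For the compounds shown here, this rests on only two pairs, however, and it does not show that the step would hold on any other core, nor does it explain what lies behind the step.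

The compounds shown carry only methoxy or hydrogen at this place, so it remains open how a chlorine atom, an amine or a carboxylic acid there would compare. They also leave open whether a longer chain such as ethoxy would behave like methoxy at this place.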